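Amide chain length in the arylsulfonate series

The source may hold more compounds than are shown below. What is called first, only, known or untested is meant among the compounds shown, and "the series" means these compounds.

Within the three compounds measured in a functional assay on MCF7 cells (Homo sapiens) for antiproliferative activity, read by sulforhodamine B assay, with a stated time of 48 h (on this read-out lower numbers stand for stronger inhibition and higher numbers for weaker inhibition), compound 3 `CCCCCC(=O)Nc1ccc(S(=O)(=O)Oc2ccccc2C(C)C)cc1` stands at the lowest number, giving 5300 nM. Compound 2 `CCC(=O)Nc1ccc(S(=O)(=O)Oc2ccccc2C(C)C)cc1` gives 11000 nM, and compound 1 `CC(=O)Nc1ccc(S(=O)(=O)Oc2ccccc2C(C)C)cc1` gives 16000 nM. The measured steps all concern the chain on the amide carbonyl: a 1.5-fold lower number from compound 1 to compound 2 (0.16 log units; within the scatter); a 3.0-fold lower number from compound 1 to compound 3 (0.48 log units; beyond the scatter); a 2.1-fold lower number from compound 2 to compound 3 (0.32 log units; beyond the scatter). Lengthening the chain has so far gone with lower numbers, though only the steps to compound 3 lie beyond the scatter.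

Compound 4 `CC(C)C(=O)Nc1ccc(S(=O)(=O)Oc2ccccc2C(C)C)cc1` differs from compound 3 by isopropyl in place of pentyl on a carbonyl carbon. Going by the values given here, no measured step covers a branched group on this carbonyl carbon; the only guide is the chain count. Isopropyl carries fewer carbons than the pentyl it replaces and more than the methyl of compound 2, so the step from compound 2 to compound 3 and the step from compound 1 to compound 3 are the ones that bear on it, and both point to a modestly higher number for compound 4 than for compound 3, likely near the edge of the scatter.

For compound 4 the expected value in this assay is 9000 nM, with a range from 4500 nM to 18000 nM. This expectation corresponds to a step of a 1.7-fold higher number from compound 3 to compound 4 (0.23 log units; within the scatter).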

Compound 4, half-maximal inhibitory concentration: 8600 nM
The estimate for compound 4 lay 1.0-fold (0.02 log units) above the measured number, within the range that was stated.
By their numbers in this assay, from the lowest: compounds 3, 4, 2 and 1 (each within the scatter of the next, the first and the last beyond it).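

Going by these compounds alone, compound 4 is the first branched group on this carbonyl carbon, and in this assay it cannot be told apart from any of the three straight-chain compounds: the steps are a 1.6-fold higher number from compound 3 to compound 4 (0.21 log units; within the scatter) and a 1.3-fold lower number from compound 2 to compound 4 (0.11 log units; within the scatter) and a 1.9-fold lower number from compound 1 to compound 4 (0.27 log units; within the scatter) in turn. Compounds 1 and 3 themselves stand further apart (a 3.0-fold lower number from compound 1 to compound 3 (0.48 log units; beyond the scatter)), so isopropyl sits within the scatter of both ends of the set, and the branched chain gives no sign of a break from the values of the straight chains, nor can it be placed at any one point among them. The data offer nothing that would account for these numbers, so the result stands here as a plain observation.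

Still open, from the compounds shown here alone, is whether a chain longer than pentyl would extend the separation seen between compounds 1 and 3, or whether a more heavily branched tert-butyl group or a ring such as cyclohexyl or phenyl on this carbonyl carbon would move the number beyond the scatter. Also open, going by these compounds, is whether a carboxylic acid or an amine at the end of the chain would be tolerated in the same way as the plain carbon chains.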